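A few compounds are considered here, and "the series" means these few. Any claim that something is new, unique, unknown or untested is made for them only; others in the source may bear on it.

Among the measured compounds shown here, compound 2 `CSc1ccc(Nc2ncnc3sc(Nc4c(Cl)cccc4Cl)nc23)cc1` gives 96 nM in a functional assay on HEK293 cells for antagonist activity at transient receptor potential cation channel subfamily V member 1 (Homo sapiens), read by calcium flux (on this read-out lower numbers stand for stronger inhibition and higher numbers for weaker inhibition), the higher of the two numbers measured so far; compound 1 `FC(F)(F)c1ccc(Nc2ncnc3sc(Nc4c(Cl)cccc4Cl)nc23)cc1` gives 12 nM in this assay. For the measured compounds named here, the only measured step, an 8.0-fold higher number from compound 1 to compound 2 (0.90 log units; beyond the scatter), shows that exchanging the group para to the large group moves the number well beyond the scatter. Compound 3 `CS(=O)(=O)c1ccc(Nc2ncnc3sc(Nc4c(Cl)cccc4Cl)nc23)cc1` differs from compound 2 in one place: methylsulfonyl in place of methylsulfanyl on an aromatic carbon. Going by the values given here, no measured pair contains a methylsulfonyl group, so the step from compound 2 to compound 3 has no direct precedent; the step from compound 1 to compound 2 shows only that this position answers to a change of substituent. Because of an 8.0-fold higher number from compound 1 to compound 2 (0.90 log units; beyond the scatter) a shift of similar size in either direction cannot be ruled out, and the estimated step is a 1.6-fold lower number from compound 2 to compound 3 (0.20 log units; within the scatter), with its direction uncertain. Compound 3 is expected to give 60 nM in this assay, within a range from 15 nM to 300 nM.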

Compound 3, half-maximal inhibitory concentration: 5 nM
Compound 3: middle estimate off by 12-fold (1.08 log units), on the high side, outside the stated range (below it).
By their numbers in this assay, from the lowest: compound 3; then compound 1; then compound 2.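

In this assay, the change of methylsulfanyl to methylsulfonyl on this aromatic carbon gives a 19-fold lower number from compound 2 to compound 3 (1.28 log units; beyond the scatter), so the earlier sensitivity of this position now has a direction for this particular change. Methylsulfonyl also goes past trifluoromethyl, with a 2.4-fold lower number from compound 1 to compound 3 (0.38 log units; beyond the scatter), which makes methylsulfanyl the outlier on the weak side and methylsulfonyl the group with the lowest number of the three. No measurement here accounts for this order of the groups.

The compounds shown leave open how an amine, a nitrile or a carboxylic acid would read at this place, and whether a longer chain on the sulfonyl sulfur would keep the number as low. They also leave open whether the same order of the three groups would hold with the dichlorophenyl amine replaced by another group.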